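Swapping Chain Branching on the Carbamoyl Nitrogen

This account rests on a few compounds, and the source may have more. Where it says the series, first, only, none or still open, it means among the compounds named here.

Compound 1 `COc1cc(C(=O)N2CCN(C(=O)c3cc(OC)c(OC)c(OC)c3)C(COC(=O)CC(C)(C)C)C2)cc(OC)c1OC` carries a neopentyl group on a carbonyl carbon of the shared core; in a functional assay (Oryctolagus cuniculus) for inhibition of platelet-activating factor receptor (Cavia porcellus) (a higher number here means a weaker inhibitor, a lower number a stronger inhibitor), compound 1 gives 120 nM. Compound 2 `CCC(C)(C)NC(=O)OCC1CN(C(=O)c2cc(OC)c(OC)c(OC)c2)CCN1C(=O)c1cc(OC)c(OC)c(OC)c1` has (1,1-dimethylpropyl)amino in that place, and in this assay compound 2 gives 320 nM. Compound 3 `CCC(C)CNC(=O)OCC1CN(C(=O)c2cc(OC)c(OC)c(OC)c2)CCN1C(=O)c1cc(OC)c(OC)c(OC)c1` has (2-methylbutyl)amino instead, and in this assay compound 3 gives 470 nM. Among the three measured compounds, compound 3 has the highest number, meaning the weakest inhibition: the step of a 3.9-fold higher number from compound 1 to compound 3 (0.59 log units; beyond the scatter) lies beyond the scatter, while the step of a 1.5-fold higher number from compound 2 to compound 3 (0.17 log units; within the scatter) does not, so compound 2 and compound 3 cannot be told apart.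

Compound 4 `CCC(CC)NC(=O)OCC1CN(C(=O)c2cc(OC)c(OC)c(OC)c2)CCN1C(=O)c1cc(OC)c(OC)c(OC)c1` has not yet been measured. It differs from compound 3 by pentan-3-yl in place of 2-methylbutyl on an amide-type nitrogen. Among the compounds with values here, the one measured step that bears directly on this kind of change, two different five-carbon groups on the amide-type nitrogen, is a 1.5-fold higher number from compound 2 to compound 3 (0.17 log units; within the scatter), which stayed within the scatter. The steps of a 2.7-fold higher number from compound 1 to compound 2 (0.43 log units; beyond the scatter) and a 3.9-fold higher number from compound 1 to compound 3 (0.59 log units; beyond the scatter) did shift the number, but they involve a different linkage to the carbonyl carbon. For compound 4 the step is therefore expected to be small, a 1.2-fold lower number from compound 3 to compound 4 (0.07 log units; within the scatter), with no clear direction. The expected value for compound 4 in this assay is 400 nM, with a range from 200 nM to 850 nM.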

Compound 4, half-maximal inhibitory concentration: 130 nM
Compound 4: the middle estimate sits 3.1-fold (0.49 log units) above what was measured; the measured number lies below the stated range.
By their numbers in this assay, from the lowest: compounds 1 and 4 (each within the scatter of the next); then compounds 2 and 3 (each within the scatter of the next).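

Where the branch falls within a five-carbon group on the amide-type nitrogen can matter in this assay: with the same atoms joined differently, pentan-3-yl in place of 2-methylbutyl gives a 3.6-fold lower number from compound 3 to compound 4 (0.56 log units; beyond the scatter) and pentan-3-yl in place of 1,1-dimethylpropyl gives a 2.5-fold lower number from compound 2 to compound 4 (0.39 log units; beyond the scatter) as a second step of similar kind. The earlier match between 2-methylbutyl and 1,1-dimethylpropyl therefore does not extend to every five-carbon group on this nitrogen, and compound 4 is set apart from both of the other carbamoyl compounds. The gap that those two left to compound 1 is also absent here, since (pentan-3-yl)amino in place of neopentyl on a carbonyl carbon gives a 1.1-fold higher number from compound 1 to compound 4 (0.03 log units; within the scatter) and so stays within the scatter.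

No measurement beyond these inhibition numbers accounts for the difference between these isomeric groups. As far as these compounds go, whether a straight pentyl chain, a cyclopentyl ring or a shorter isopropyl group on the same nitrogen would track pentan-3-yl or the other two carbamoyl groups stays open.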